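Losing the Methyl That Made Compound 3 Stand Out

The source may hold more compounds than are shown below. What is called first, only, known or untested is meant among the compounds shown, and "the series" means these compounds.

Three compounds share one core and were compared in an assay on MDA-MB-231 cells for binding affinity to C-X-C chemokine receptor type 4 (Homo sapiens), read by immunofluorescence and microscopy, with stated times of 10 min and 30 min; a lower number here means that less compound is needed, a higher number that more compound is needed for the effect. Compound 3 `Cc1ccccc1C(=O)NCc1ccc(CNS(=O)(=O)c2ccccc2)cc1` gives 1 nM, the lowest of the three numbers. Compound 1 `O=C(NCc1ccc(CNS(=O)(=O)c2ccccc2)cc1)c1ccc(F)cc1` gives 100 nM, and compound 2 `O=C(NCc1ccc(CNS(=O)(=O)c2ccccc2)cc1)c1ccccc1F` gives 1000 nM. The steps are a 100-fold lower number from compound 1 to compound 3 (2.00 log units; beyond the scatter), a 1000-fold lower number from compound 2 to compound 3 (3.00 log units; beyond the scatter) and a 10-fold higher number from compound 1 to compound 2 (1.00 log units; beyond the scatter), all beyond the scatter.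

Compound 4 `O=C(NCc1ccc(CNS(=O)(=O)c2ccccc2)cc1)c1ccccc1` differs from compound 3 by hydrogen in place of methyl on an aromatic carbon. The methyl is removed from its place on an aromatic carbon of a six-membered aromatic ring of carbon only, ortho to a large group, so that 2-methylphenyl becomes phenyl. Within the data shown here, no measured pair shows this exact change, but the two steps into compound 3 show that what sits on that ring shifts the number by large amounts, and compound 3 with the methyl gives the lowest number. A higher number than compound 3 is therefore expected, larger than the scatter but uncertain in size. Compound 4 is estimated at 30 nM, with a range from 5 nM to 300 nM. The expected step is a 30-fold higher number from compound 3 to compound 4 (1.48 log units; beyond the scatter).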

Compound 4, effective concentration (reported as EC, without a stated level of effect): 1 nM
Beside the measured number, compound 4's estimate is 30-fold (1.48 log units) above it; the measured number lies below the stated range.
By their numbers in this assay, from the lowest: compounds 3 and 4 (each within the scatter of the next); then compound 1; then compound 2.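

In this assay removing the methyl gives no change at the digits printed from compound 3 to compound 4 (within the scatter) and so this group, on an aromatic carbon ortho to a large group, is not what gives the low number. The earlier steps shown here could be read as a gain from methyl, but fluoro now stands out instead: putting hydrogen in its place gives a 100-fold lower number from compound 1 to compound 4 (2.00 log units; beyond the scatter) and a 1000-fold lower number from compound 2 to compound 4 (3.00 log units; beyond the scatter) and thus it is the two fluoro compounds that sit apart from the other two. Nothing shown here gives a reason for these steps. The compounds shown leave open whether a larger group at this place, such as an ethyl, a methoxy or an amine, would keep the number as low. They also leave open whether chloro, another halogen, would raise the number as fluoro does.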